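Swapping the ring on the sulfonyl of compound 2

This account rests on a few compounds, and the source may have more. Where it says the series, first, only, none or still open, it means among the compounds named here.

Of the compounds shown here, two have been measured in an assay on isolated protein for inhibition of Nicotinamide phosphoribosyltransferase (Homo sapiens), read by mass spectrometry, with stated times of 15 min and 30 min; on this read-out higher numbers stand for weaker inhibition and lower numbers for stronger inhibition. Compound 1, `O=C(NCc1ccc(S(=O)(=O)c2ccccc2)cc1)N1CCc2ccncc2C1`, gives 310 nM in this assay. Compound 2, `O=C(NCc1ccc(S(=O)(=O)C2CCC(F)(F)CC2)cc1)N1Cc2ccncc2C1`, gives 78 nM in this assay, the lower of the two numbers, and its gap to compound 1 lies beyond the usual scatter. Going by the values given here, the two compounds differ in more than one place, so no single step between them can be drawn; only the two values themselves are on hand.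

Compound 3, `CN1CCC(S(=O)(=O)c2ccc(CNC(=O)N3Cc4ccncc4C3)cc2)CC1`, is the next compound. It differs from compound 2 in one place: 1-methylpiperidin-4-yl in place of 4,4-difluorocyclohexyl on a sulfonyl sulfur. Among the compounds with values here, no measured pair shows the effect of this exchange, so nothing beyond the two values already given can support a forecast. The change keeps the sulfonyl and the rest of compound 2 intact and exchanges one six-membered non-aromatic ring for another. The step of a 1.4-fold higher number from compound 2 to compound 3 (0.15 log units; within the scatter) is therefore expected to be small, most likely within the scatter or slightly toward weaker inhibition. Compound 3 is expected to give an estimated 110 nM in this assay, with a likely range from 35 nM to 350 nM.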

Compound 3, half-maximal inhibitory concentration: 48 nM
The estimate for compound 3 lay 2.3-fold (0.36 log units) above the measured number; the range from low to high includes it.
By their numbers in this assay, from the lowest: compounds 3 and 2 (each within the scatter of the next); then compound 1.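

In this assay, going by these compounds alone, 1-methylpiperidin-4-yl in place of 4,4-difluorocyclohexyl on a sulfonyl sulfur gives a 1.6-fold lower number from compound 2 to compound 3 (0.21 log units; within the scatter) and so provides the first step in which only one place changes. At this position, the carbon-only ring with its two fluorines and the six-membered ring with one hetero atom cannot be told apart on this read-out, although the two groups differ in their hetero atoms and in their count of hydrogen-bond acceptors. No measurement on hand bears on the reason for this outcome.

The compounds shown leave open whether the ring nitrogen or its methyl group has any bearing on the value, a question that piperidin-4-yl, 1-acetylpiperidin-4-yl or tetrahydropyran-4-yl on the same sulfonyl sulfur could address. Going by these compounds, compound 1 differs from compound 2 and compound 3 in more than one place, so it also remains open how a phenyl ring on the sulfonyl sulfur compares with these non-aromatic rings on an otherwise identical core.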